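The source may hold more compounds than are shown below. What is called first, only, known or untested is meant among the compounds shown, and "the series" means these compounds.

Measured in an ADME assay on microsomes from liver (Rattus norvegicus) for metabolic stability, with a stated time of 30 min, tested at 1 uM; on this read-out higher numbers stand for a more stable compound and lower numbers for a less stable compound:
compound 1 `CC[C@@H]1C(=O)N(C)c2cnc(-n3ccnc3-c3ccccc3)nc2N1[C@@H]1CCOC1`: 0%
compound 2 `CC[C@@H]1C(=O)N(C)c2cnc(-n3ccnc3-c3ccc(F)cc3)nc2N1[C@H]1CCOC1`: 67%

Of the two measured compounds, compound 1 stands lowest at 0%. Compound 2 gives 67%, and its gap to compound 1 lies beyond the scatter.

Next in line is compound 3 `CC[C@@H]1C(=O)N(C)c2cnc(-n3ccnc3-c3ccccc3)nc2N1C1CCCC1`, not yet measured in this assay. It carries cyclopentyl in place of oxolan-3-yl on a nitrogen on an aromatic ring in a ring, and the rest of the core of compound 1 is unchanged. Among the compounds with values here, no two measured compounds differ in one place only, so the data give no direct size for this change, and the estimate is correspondingly soft.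

The read-out leaves no room for a fall, because compound 1 gives 0%. Any real movement could therefore only be upward, but no step beyond the scatter is expected in this assay. The expected outcome is a number 3 percentage points higher from compound 1 to compound 3 (within the scatter), a small step within the scatter. For compound 3 the estimated value is 3%, with an expected range of 0% to 15%.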

Compound 3, percent of the compound remaining: 0%
The estimate for compound 3 lay 3 percentage points above the measured number; low and high end bracket the measured number.
By their numbers in this assay, from the lowest: compounds 1 and 3 (each within the scatter of the next); then compound 2.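

In this assay, within the data shown here, cyclopentyl in place of oxolan-3-yl on a nitrogen on an aromatic ring in a ring gives no change at the digits printed from compound 1 to compound 3 (within the scatter), the first single-place step at this position. Exchanging the ring oxygen for carbon, with the loss of the hydrogen-bond acceptor and the defined stereocentre of oxolan-3-yl, therefore does not lift the read-out off the bottom of the scale, where compound 3 gives 0%. With both compounds at the end of the scale, any difference in stability between them cannot be read from this step, and nothing available explains the result.

Compound 2, at 67%, differs from both of these compounds in more than one place, so no single-place step connects it to them and the change behind its number remains unassigned. Also open, going by these compounds, is whether a different kind of group on this nitrogen, such as a piperidine amine or a longer alkyl chain, would move the number off the bottom of the scale on the unsubstituted phenyl series.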